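The compounds below may be only part of what the source reports. "The series", "measured", "known", "first", "only" and "open" are said of these compounds alone.

Measured compounds:
Compound 1, `CCCCc1nc(N)nc(N)c1-c1ccc(Cl)cc1`, in an assay for inhibition of beta-N-acetyl-D-hexosaminidase-A/B (Homo sapiens); on this read-out lower numbers stand for stronger inhibition and higher numbers for weaker inhibition: compound 1 gives > 1400000 nM, a limit of the assay rather than a number.
Compound 2, `CCc1nc(N)nc(N)c1-c1cc(C)cc(C)c1`: compound 2 gives 47000 nM in this assay.

Compound 1 therefore stands at the weak end of what is shown, its result being only a limit; this is the situation described by the limit of > 1400000 nM in this assay, at which 1 of the 2 values shown sits. For the measured compounds named here, compound 2, which differs from compound 1 in more than one place, gives a number instead of a limit, so the two values show only that compound 2 is measurable where compound 1 is not.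

Compound 3, `CC(C)c1nc(N)nc(N)c1-c1ccc(Cl)cc1`, has not yet been measured in this assay. It differs from compound 1 by isopropyl in place of butyl on an aromatic carbon. Going by the values given here, because compound 1 sits at > 1400000 nM, a limit, no measured step guides this change, and the expected step from compound 1 to compound 3 in this assay is a step that the limit leaves unreadable from compound 1 to compound 3, that is, none beyond the usual scatter. Compound 3 is accordingly expected to give about 2000000 nM, within a range from 400000 nM to 10000000 nM, most likely again reported only as a limit.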

Compound 3, half-maximal inhibitory concentration: > 410000 nM
Compound 3 ended at the assay's limit; the forecaster's own chance of this, stated with the estimate: 70%; the middle value is on the limit's open side.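

In this assay, for the compounds shown here, compound 1 and compound 3 both give only limits of the assay, so no step between them can be read. The compounds shown leave open whether butyl and isopropyl on this aromatic carbon differ in inhibition at all.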